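This account rests on a few compounds, and the source may have more. Where it says the series, first, only, none or still open, it means among the compounds named here.

Measured so far in an ADME assay on HUVEC cells (Homo sapiens) for antiproliferative activity, read by MTT assay, with a stated time of 48 h; a lower number here means a stronger inhibitor, a higher number a weaker inhibitor:
compound 1 `N#CC1=C(N)Oc2c(N)cc3nc4ccccc4nc3c2C12C(=O)N(Cc1cnnn1-c1ccccc1Br)c1ccccc12` gives 34200 nM.
compound 2 `CCOc1ccccc1-n1nncc1CN1C(=O)C2(C(C#N)=C(N)Oc3c(N)cc4nc5ccccc5nc4c32)c2ccccc21` gives > 50000 nM, a limit of the assay.
compound 3 `N#CC1=C(N)Oc2c(N)cc3nc4ccccc4nc3c2C12C(=O)N(Cc1cnnn1-c1ccc([N+](=O)[O-])cc1)c1ccccc12` gives > 50000 nM, a limit of the assay.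

Compound 3 thus stands at the limit of > 50000 nM in this assay, at which 2 of the 3 values shown sit, with no number of its own. Compound 4 `CCc1cccc(CC)c1-n1nncc1CN1C(=O)C2(C(C#N)=C(N)Oc3c(N)cc4nc5ccccc5nc4c32)c2ccccc21` differs from it by 2,6-diethylphenyl in place of 4-nitrophenyl on an aromatic nitrogen. Of the measured steps, an at least 1.4-fold higher number from compound 1 to compound 3 (0.16 log units; that floor lies within the scatter) and a step that the two limits leave unreadable from compound 2 to compound 3 concern the same aromatic nitrogen, as does an at least 1.4-fold higher number from compound 1 to compound 2 (0.16 log units; that floor lies within the scatter); all three are bounded by limits and none shows a readable size. Every change so far at that aromatic nitrogen has left the series weak in this assay. Compound 4 is therefore expected to sit near the same limit, with a step of a number no higher from compound 3 to compound 4 (the limit leaves the size open) of no readable size. The estimate for compound 4 is 50000 nM, in the range 20000 nM to 120000 nM.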

Compound 4, half-maximal inhibitory concentration: > 50000 nM
Compound 4: no number, only a limit (the forecaster's own chance of this, stated with the estimate: 60%); the middle value lies on the limit itself.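

In this assay compound 4 gives > 50000 nM, a limit of the assay, so a carbon-only group on the aromatic nitrogen, 2,6-diethylphenyl, also yields no number. Among the compounds shown here, the one readable step is an at least 1.4-fold higher number from compound 1 to compound 4 (0.16 log units; that floor lies within the scatter), while the steps among the compounds at the limit cannot be read. With compound 1 the only exception, 2-ethoxyphenyl, 4-nitrophenyl and 2,6-diethylphenyl all end at one ceiling: the limit of > 50000 nM in this assay, at which 3 of the 4 values shown sit.

Open, on these data alone, is whether any of these three groups differ in strength beyond the limit. Also open, as far as these compounds go, is whether an amine or carboxylic acid on this phenyl ring would give a measurable value.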